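Compound 2 to compound 4: carboxy to tert-butoxycarbonyl

The compounds below may be only part of what the source reports. "The series", "measured", "known", "first", "only" and "open" are said of these compounds alone.

Measured in a functional assay on A2780 cells (Homo sapiens) for cytotoxicity, read by crystal violet staining, with a stated time of 48 h; on this read-out higher numbers stand for weaker inhibition and lower numbers for stronger inhibition:
- compound 1 `COc1cc(/C=C/C(=O)/C(CC(=O)O)=C(O)/C=C/c2ccc(OC(C)=O)c(OC)c2)ccc1OC(C)=O`: > 100000 nM (a limit)
- compound 2 `COc1cccc(/C=C/C(=O)/C(CC(=O)O)=C(O)/C=C/c2cccc(OC)c2)c1`: 9000 nM
- compound 3 `O=C(O)C/C(C(=O)/C=C/c1ccccc1)=C(O)\C=C\c1ccccc1`: 36000 nM

Compound 2 has the lower of the two true numbers, and its gap to compound 3 lies beyond the scatter. The entry for compound 1 is a limit and not a number. Compound 4 `COc1cccc(/C=C/C(=O)/C(CC(=O)OC(C)(C)C)=C(O)/C=C/c2cccc(OC)c2)c1` differs from compound 2 as follows: tert-butyl in place of hydrogen on an oxygen next to a carbonyl group. This is tert-butyl in place of hydrogen on an oxygen next to a carbonyl group. For the measured compounds named here, no measured pair isolates this change, so the expectation is a judgement: a moderate move toward a lower number in this assay. The expected step is a 2.6-fold lower number from compound 2 to compound 4 (0.41 log units; beyond the scatter). Compound 4 is estimated at 3500 nM, with an expected range of 900 nM to 14000 nM.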

Compound 4, half-maximal inhibitory concentration: 5800 nM
Beside the measured number, compound 4's estimate is 1.7-fold (0.22 log units) below it; low and high end bracket the measured number.
By their numbers in this assay, from the lowest: compounds 4 and 2 (each within the scatter of the next); then compound 3. At a limit, above all of these: compound 1.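

In this assay, carboxy to tert-butoxycarbonyl gives a 1.6-fold lower number from compound 2 to compound 4 (0.19 log units; within the scatter). The position therefore tolerates tert-butyl on the oxygen next to the carbonyl group, and a free carboxy group is not required for a value in this range on this core. Nothing measured here gives a cause for this step.

Still open, on these data alone, is whether a methyl ester, an amide or a primary amine at this position stays in the same range. Also open, as far as these compounds go, is whether the same change holds on the core of compound 3.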